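The compounds below may be only part of what the source reports. "The series", "measured", "known", "first", "only" and "open" are said of these compounds alone.

Going by the values given here, compound 1 `Cc1noc(C)c1-c1cnc(N)c(Oc2ccc(C(=O)Nc3ccccc3)cc2)n1` is one of three compounds measured in a functional assay on LoVo cells (Homo sapiens) for inhibition, read by MTT assay, with a stated time of 72 h (a lower number here means a stronger inhibitor, a higher number a weaker inhibitor), where compound 1 gives 5740 nM. That number is the second highest of the three. Compound 2 `Cc1noc(C)c1-c1cnc(N)c(Oc2ccc(C(=O)Nc3ccc(Cl)cc3)cc2)n1` gives 1920 nM, and compound 3 `Cc1noc(C)c1-c1cnc(N)c(Oc2ccc(C(=O)Nc3ncccc3Cl)cc2)n1` gives 14800 nM. The measured steps all concern the amide side of the molecule: a 3.0-fold lower number from compound 1 to compound 2 (0.48 log units; beyond the scatter), a 2.6-fold higher number from compound 1 to compound 3 (0.41 log units; beyond the scatter), and a 7.7-fold higher number from compound 2 to compound 3 (0.89 log units; beyond the scatter). Each of these is beyond the scatter but modest in size.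

Compound 4 `Cn1cc(-c2cnc(N)c(Oc3ccc(C(=O)Nc4ccccc4)cc3)n2)cn1` changes a different part of compound 1: 1-methyl-1H-pyrazol-4-yl in place of 3,5-dimethyl-1,2-oxazol-4-yl on an aromatic carbon. Among the compounds with values here, none of the three measured steps touches this position, so there is no direct precedent among the measured compounds for what this exchange does in this assay. The amide-side steps show that single-group changes in this series move the number by modest amounts in either direction, which gives a sense of scale but not of direction.

On that basis, compound 4 is expected to come out near compound 1, with the step of a 1.1-fold lower number from compound 1 to compound 4 (0.06 log units; within the scatter) expected to stay within the range of modest change seen elsewhere. The estimate for compound 4 is 5000 nM, with an expected range from 1500 nM to 18000 nM.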

Compound 4, half-maximal inhibitory concentration: 9210 nM
For compound 4 the middle estimate is 1.8-fold (0.27 log units) below the measured one, within the range that was stated.
By their numbers in this assay, from the lowest: compound 2; then compounds 1, 4 and 3 (each within the scatter of the next, the first and the last beyond it).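

In this assay, going by these compounds alone, putting 1-methyl-1H-pyrazol-4-yl in place of 3,5-dimethyl-1,2-oxazol-4-yl gives a 1.6-fold higher number from compound 1 to compound 4 (0.21 log units; within the scatter), the first reading for a change away from the amide side of the molecule. At this aromatic carbon, para to an amino group, one five-membered aromatic ring with 2 hetero atoms can therefore stand in for the other with no difference that can be told from the scatter, and both groups count 0 hydrogen-bond donors and 2 hydrogen-bond acceptors. Nothing available explains this outcome, so the result stands as an observation about this one pair.

The compounds shown leave open whether the same exchange would read alike with the 4-chlorophenyl amide of compound 2 or the 3-chloropyridin-2-yl amide of compound 3, since this position is seen only with the unsubstituted phenyl amide. They also leave open how far the position would accept something other than a five-membered aromatic ring with 2 hetero atoms, such as a morpholine, a carboxylic acid or a longer chain ending in an amine.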